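Swapping the dichlorophenyl amide for an iodophenyl amide

A few compounds are considered here, and "the series" means these few. Any claim that something is new, unique, unknown or untested is made for them only; others in the source may bear on it.

Compound 1 `Cc1cc(C(=O)Nc2cc(Cl)cc(Cl)c2)nn1-c1cccc(C(F)(F)F)c1` gives 150 nM in an assay on HEK293 cells for binding affinity to Neuropeptide Y receptor type 5 (Homo sapiens), read by radioligand binding; on this read-out higher numbers stand for weaker inhibition and lower numbers for stronger inhibition. Its nearest neighbour, compound 2 `Cc1cccc(-n2nc(C(=O)Nc3cc(Cl)cc(Cl)c3)cc2C)c1`, gives 218 nM in this assay, and the gap is within the scatter, so the two cannot be told apart. Within the data shown here, the single measured step, a 1.5-fold higher number from compound 1 to compound 2 (0.16 log units; within the scatter), concerns the trifluoromethyl and says nothing about the group on the amide-type nitrogen.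

Compound 3 `Cc1cc(C(=O)Nc2cccc(I)c2)nn1-c1cccc(C(F)(F)F)c1` changes exactly that group: 3-iodophenyl in place of 3,5-dichlorophenyl on an amide-type nitrogen. Among the measured compounds shown here, no measured step bears on this change, so there is no basis for predicting a direction. For the measured compounds named here, the only precedent, the step from compound 1 to compound 2, stayed within the scatter. Compound 3 is therefore expected to give 250 nM in this assay, with a range from 80 nM to 800 nM. The expected step is a 1.7-fold higher number from compound 1 to compound 3 (0.22 log units; within the scatter), a guess that allows for a modest loss given the single ring substituent that enters.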

Compound 3, half-maximal inhibitory concentration: 670 nM
For compound 3 the middle estimate is 2.7-fold (0.43 log units) below the measured one, within the range that was stated.
By their numbers in this assay, from the lowest: compounds 1 and 2 (each within the scatter of the next); then compound 3.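

Unlike the step at the trifluoromethyl, which stayed within the scatter, the change on the amide-type nitrogen gives a 4.5-fold higher number from compound 1 to compound 3 (0.65 log units; beyond the scatter) in this assay, so the numbers in this small set do respond to the aryl group at this place. The step is a combined one: the ring stays, but 3,5-dichlorophenyl carries two chlorines, and 3-iodophenyl carries one iodine and no chlorine. Nothing measured here accounts for the higher number.

The compounds shown leave open whether the step follows from the loss of one substituent or from iodine taking the place of chlorine. A 3-chlorophenyl or a 3,5-diiodophenyl group on the same core would separate these two readings.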